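The source may hold more compounds than are shown below. What is called first, only, known or untested is meant among the compounds shown, and "the series" means these compounds.

Compound 1 `O=C(Nc1cccc(-n2cc(-c3ccncc3)c(-c3cc(O)cc(Cl)c3)n2)c1)Nc1ccc(Cl)c(C(F)(F)F)c1` gives 101% in a functional assay on RPMI-8226 cells (Homo sapiens) for inhibition, read by sulforhodamine B assay, with a stated time of 48 h, tested at 0.01 uM; a higher number here means a weaker effect of the compound at the concentration tested, a lower number a stronger effect. Compound 2 `COc1cc(Cl)cc(-c2nn(-c3cccc(NC(=O)Nc4ccc(Cl)c(C(F)(F)F)c4)c3)cc2-c2ccncc2)c1` gives 97% in this assay.

Compound 2 has the lower of these two numbers, with compound 1 nearest, and the step of a number 4 percentage points lower from compound 1 to compound 2 (within the scatter) lies within the scatter. Compound 3 `COc1cc(Cl)cc(-c2nn(-c3cccc(NC(=O)c4cccc(C(F)(F)F)c4)c3)cc2-c2ccncc2)c1` differs from compound 2 in one place: 3-(trifluoromethyl)phenyl in place of (4-chloro-3-(trifluoromethyl)phenyl)amino on a carbonyl carbon. Among the compounds with values here, the single measured step changes a different part of the shared core and was itself within the scatter, so no measured step speaks directly to this change. With both measured numbers near full activity, compound 3 is expected to give 98%, between 85% and 110%, an expected step of a number 1 percentage points higher from compound 2 to compound 3 (within the scatter), not beyond the scatter.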

Compound 3, a percentage reported as activity, at one concentration (the size of the read-out at that concentration, not a potency): 101%
Beside the measured number, compound 3's estimate is 3 percentage points below it, within the range that was stated.
By their numbers in this assay, from the lowest: compounds 2, 1 and 3 (each within the scatter of the next).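

With the (4-chloro-3-(trifluoromethyl)phenyl)amino group on the carbonyl carbon replaced by 3-(trifluoromethyl)phenyl, the result is a number 4 percentage points higher from compound 2 to compound 3 (within the scatter) in this assay. This is the first change shown at this end of the molecule, and it shows that this swap, which also removes the hydrogen-bond donor counted in the group that leaves, does not separate the two compounds at this concentration. Nothing available bears on the reason for this. Still open, as far as these compounds go, is whether a different group on that carbonyl carbon, such as a morpholine or a short alkyl chain, would separate from compound 2 in this assay.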